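The compounds below may be only part of what the source reports. "The series", "measured", "known", "first", "only" and "open" are said of these compounds alone.

Measured in an ADME assay on L6 cells (Rattus norvegicus) for cytotoxicity; on this read-out higher numbers stand for weaker inhibition and lower numbers for stronger inhibition:
Compound 1 `CCN(CC)CC(=O)OC1CC2(N(C)C)CC(c3ccccc3)C1C(c1ccccc1)C2`: 30100 nM
Compound 2 `CCN(CC)CC(=O)OC1CC2(N3CCCCC3)CC(c3ccccc3)C1C(c1ccccc1)C2`: 23900 nM; 61300 nM (2 entries)

In this assay, among the compounds with values here, compound 1, at 30100 nM, has only this one number, and a further entry gives no single value. That number lies within the spread of the several entries of compound 2 in this assay, 23900 nM; 61300 nM (2 entries). Compound 3 `CCN(CC)CCC(=O)OC1CC2(N(C)C)CC(c3ccccc3)C1C(c1ccccc1)C2` carries (diethylamino)methyl in place of diethylamino on a saturated chain carbon bound to a carbonyl carbon. Within the data shown here, no measured step covers this change, so no shift beyond the usual scatter is expected in either direction. The expected change is small: a 1.1-fold lower number from compound 1 to compound 3 (0.03 log units; within the scatter). For compound 3 the estimated value is 28000 nM, with an expected range of 10000 nM to 75000 nM.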

Compound 3, half-maximal inhibitory concentration: 23600 nM
Compound 3: middle estimate off by 1.2-fold (0.07 log units), on the high side, within the range that was stated.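

In this assay, the only step shown at this saturated chain carbon bound to a carbonyl carbon, (diethylamino)methyl in place of diethylamino, gives a 1.3-fold lower number from compound 1 to compound 3 (0.11 log units; within the scatter). The extra carbon in the chain therefore produces no shift beyond the usual scatter on this read-out. The step is also small beside the disagreement between repeat entries of a single close analogue: the several entries of compound 2 in this assay, 23900 nM; 61300 nM (2 entries)

From the compounds shown here alone, it remains open whether a longer chain, such as 3-(diethylamino)propyl, would move the number. The same holds for a morpholine in place of the diethylamino end.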